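From Pyridyl to Bromo on a Shared Core

The source may report more compounds than this note shows. Statements on the series, on what has been measured and on what is new or still open speak of the compounds shown alone.

For the measured compounds named here, compound 2 `CC1(C)C=C(n2ccccc2=O)c2cc(-c3ccncc3)ccc2O1` gives 6.32 in a functional assay (trachea) with Rattus norvegicus as the target (a higher number here means a more potent compound, by a factor of ten per unit of this negative logarithm, a lower number a less potent compound), the higher of the two numbers measured so far; the other belongs to compound 1 `CC1(C)C=C(n2ccccc2=O)c2cc(C(=N)NO)ccc2O1`, which gives 5.51 in this assay. That step, a number 0.81 log units higher from compound 1 to compound 2 (beyond the scatter), is the only measured one, and it does not concern the group that compound 3 `CC1(C)C=C(n2ccccc2=O)c2cc(Br)ccc2O1` carries: bromo in place of pyridin-4-yl on an aromatic carbon. Going by the values given here, with no measured step on this exchange, the size of the change in this assay is open. For compound 3 a modest fall is expected, a number 0.42 log units lower from compound 2 to compound 3 (beyond the scatter). Compound 3 is therefore estimated at 5.9, between 5.2 and 6.6.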

Compound 3, logarithm of the reciprocal of the active concentration, log(1/C): 7.53
Estimate against measurement, compound 3: 1.63 log units below; measured number outside the range, above it.
By their numbers in this assay, from the lowest: compound 1; then compound 2; then compound 3.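

On this aromatic carbon of the shared core, a ring is not needed for high potency in this assay: bromo in place of pyridin-4-yl gives a number 1.21 log units higher from compound 2 to compound 3 (beyond the scatter) and the same single atom in place of the open-chain group of compound 1 gives a number 2.02 log units higher from compound 1 to compound 3 (beyond the scatter). With both steps beyond the scatter, compound 3 is the most potent of the three, and the order of the groups here is now bromo, then pyridin-4-yl, then the open-chain group. No available evidence accounts for this order.

Going by these compounds, how chloro, methyl, an amine or a carboxylic acid on this carbon would compare with bromo remains open. So does whether the order of these groups would hold with a different group on the rest of the core.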